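The source may report more compounds than this note shows. Statements on the series, on what has been measured and on what is new or still open speak of the compounds shown alone.

The three measured compounds share one core and differ only in the aryl group attached to it. Compound 1 `CCC1=C(O)c2c(oc(-c3ccc(CC(C)C)cc3)cc2=O)C(CC)(CC)C1=O` gives 17.4 uM in a functional assay on KBVIN cells (Homo sapiens) for antiproliferative activity, read by sulforhodamine B assay, with a stated time of 3 days; a lower number here means that less compound is needed, a higher number that more compound is needed for the effect; compound 2 `CCC1=C(O)c2c(oc(-c3ccc(C(F)(F)F)cc3)cc2=O)C(CC)(CC)C1=O` gives 10.4 uM; compound 3 `CCC1=C(O)c2c(oc(-c3ccc(CBr)cc3)cc2=O)C(CC)(CC)C1=O` gives 27.9 uM, the highest of the three numbers. The aryl swaps among them gave a 1.7-fold lower number from compound 1 to compound 2 (0.22 log units; within the scatter), a 1.6-fold higher number from compound 1 to compound 3 (0.21 log units; within the scatter) and a 2.7-fold higher number from compound 2 to compound 3 (0.43 log units; beyond the scatter). Compound 4 `CCC1=C(O)c2c(oc(-c3ccc(OC)cc3C)cc2=O)C(CC)(CC)C1=O` carries 4-methoxy-2-methylphenyl in place of 4-(bromomethyl)phenyl on an aromatic carbon. For the measured compounds named here, no measured compound bears a methoxy or a methyl on that ring, so these three swaps are the only guide, and they ran from within the scatter to modest. Compound 4 is therefore expected to fall back toward the other aryl variants, a 1.9-fold lower number from compound 3 to compound 4 (0.27 log units; within the scatter), with an estimate of 15 uM and a range from 6 uM to 35 uM.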

Compound 4, concentration for half-maximal effect: 2.62 uM
Compound 4: middle estimate off by 5.7-fold (0.76 log units), on the high side; measured number outside the range, below it.
By their numbers in this assay, from the lowest: compound 4; then compounds 2, 1 and 3 (each within the scatter of the next, the first and the last beyond it).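

In this assay, this aryl position on the shared core can shift the number much further than the earlier swaps showed: an 11-fold lower number from compound 3 to compound 4 (1.03 log units; beyond the scatter), whereas the largest earlier step was a 2.7-fold higher number from compound 2 to compound 3 (0.43 log units; beyond the scatter). The entering 4-methoxy-2-methylphenyl differs from 4-(bromomethyl)phenyl in more than one substituent, so the step belongs to the whole aryl exchange and not to any single group. Nothing shown here explains the size of this step.

From the compounds shown here alone, it remains open whether the methoxy or the methyl carries the step, since neither appears alone on this ring. Also open, going by these compounds, is how an aryl group bearing an amine or a carboxylic acid would read.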